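Pyrazoline Amides on HepG2 Cells: From Compound 3 to 4

The source may report more compounds than this note shows. Statements on the series, on what has been measured and on what is new or still open speak of the compounds shown alone.

Compound 1 `CC1=NN(C(=O)CCc2ccccc2)C(c2cc(Br)cc(Br)c2O)C1`: 9170 nM
Compound 2 `CC1=NN(C(=O)CN2CCCC2)C(c2ccccc2O)C1`: 5540 nM
Compound 3 `Cc1ccc(C(=O)N2N=C(c3cc4ccccc4oc3=O)CC2c2ccccc2)cc1`: 52300 nM

Of the compounds shown here, three have so far been measured in a functional assay on HepG2 cells (Homo sapiens) for cytotoxicity, read by MTT assay, with a stated time of 48 h; a lower number here means a stronger inhibitor, a higher number a weaker inhibitor. Compound 3 gives the highest number of the three; compound 1 sits below it and compound 2 lower still, and both of those gaps lie beyond the usual scatter of this assay. Compound 4 `CC1CCCCN1CC(=O)N1N=C(c2cc3ccccc3oc2=O)CC1c1ccccc1` has not yet been measured. It differs from compound 3 in one place: (2-methylpiperidin-1-yl)methyl in place of 4-methylphenyl on a carbonyl carbon. Going by the values given here, no pair of measured compounds isolates this change on a shared core. Compound 2 does carry a ring-bearing methyl group on its carbonyl carbon and gives 5540 nM in this assay, but its core is not that of compound 3, so its value can only hint at the direction. The step is expected to be downward and modest, a 1.7-fold lower number from compound 3 to compound 4 (0.24 log units; within the scatter), and not with confidence beyond the scatter. Compound 4 is accordingly estimated at 30000 nM in this assay, with a range from 8000 nM to 100000 nM.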

Compound 4, half-maximal inhibitory concentration: "not active" (no number reported)
Compound 4 has no reported number here, so the estimate cannot be set against anything.
By their numbers in this assay, from the lowest: compounds 2 and 1 (each within the scatter of the next); then compound 3.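

In this assay, going by these compounds alone, compound 4 is reported as "not active" without a number, so no step from compound 3 to compound 4 can be read. The compounds shown leave open how far (2-methylpiperidin-1-yl)methyl in place of 4-methylphenyl shifts the number on this core. No evidence bears on this result.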